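The compounds below may be only part of what the source reports. "The series", "measured", "known", "first", "only" and "open" are said of these compounds alone.

Among the measured compounds shown here, the three compounds measured so far share one core and differ only in the aryl group attached to an aromatic carbon of it. Compound 1 `Cc1cc(Cl)ccc1-c1cc(COc2ccc([C@H](CC(=O)O)c3nccn3C)cc2)ccc1C` gives 97 nM in an assay on CHO cells for agonist activity at Free fatty acid receptor 1 (Homo sapiens), read by luminescence, with a stated time of 20 s, in the presence of a further agent that is not named here; on this read-out lower numbers stand for an effect already at smaller amounts and higher numbers for an effect only at larger amounts of compound. Compound 2 `Cc1cc(F)ccc1-c1cccc(COc2ccc([C@H](CC(=O)O)c3nccn3C)cc2)c1` gives 59 nM, and compound 3 `Cc1c(Cl)cccc1-c1cccc(COc2ccc([C@H](CC(=O)O)c3nccn3C)cc2)c1` gives 61 nM. For the measured compounds named here, the single step measured in one place, a 1.0-fold higher number from compound 2 to compound 3 (0.01 log units; within the scatter), is flat. Compound 3 thus holds the second highest of the three numbers, with its gaps to compound 2 and to compound 1 both within the scatter. Compound 4 `CCc1ccccc1-c1cccc(COc2ccc([C@H](CC(=O)O)c3nccn3C)cc2)c1` has not yet been measured; it carries 2-ethylphenyl in place of 3-chloro-2-methylphenyl on an aromatic carbon. Going by the values given here, the only step bearing on this change, the one from compound 2 to compound 3, was flat. Compound 4 is therefore expected to show a 1.1-fold higher number from compound 3 to compound 4 (0.06 log units; within the scatter) in this assay. Compound 4 is estimated at 70 nM, between 30 nM and 170 nM.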

Compound 4, half-maximal effective concentration: 48 nM
Beside the measured number, compound 4's estimate is 1.5-fold (0.16 log units) above it, within the range that was stated.
By their numbers in this assay, from the lowest: compounds 4, 2, 3 and 1 (each within the scatter of the next, the first and the last beyond it).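

In this assay this position also takes 2-ethylphenyl, an aryl group of carbon only, with a 1.3-fold lower number from compound 3 to compound 4 (0.10 log units; within the scatter) and a 1.2-fold lower number from compound 2 to compound 4 (0.09 log units; within the scatter). Among these compounds, then, neither the chlorine of 3-chloro-2-methylphenyl nor the fluorine of 4-fluoro-2-methylphenyl is required for a number in this range, and ethyl is tolerated where those groups carry methyl. No evidence at hand bears on why these steps are so small. Still open, from the compounds shown here alone, is how this position responds to an amine, a carboxylic acid or a chain longer than ethyl on this aryl group.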